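From compound 3 to compound 4: a new carbonyl substituent

This account rests on a few compounds, and the source may have more. Where it says the series, first, only, none or still open, it means among the compounds named here.

In a functional assay on Shh Light II cells (Mus musculus) for inhibition, read by a luciferase reporter (on this read-out higher numbers stand for weaker inhibition and lower numbers for stronger inhibition), compound 1 (`CC(C)c1ccccc1NC(=O)N1CCC(c2nc(-c3ccc4ccccc4n3)no2)CC1`) gives 480 nM, compound 2 (`COc1ccccc1N(C)C(=O)N1CCC(c2nc(-c3ccc4ccccc4n3)no2)CC1`) gives 3100 nM and compound 3 (`O=C(Nc1ncccc1Cl)N1CCC(c2nc(-c3ccc4ccccc4n3)no2)CC1`) gives 2800 nM. Compound 3 sits at the high end of these three numbers. Its closest neighbour is separated by a 1.1-fold lower number from compound 2 to compound 3 (0.04 log units; within the scatter), within the scatter, and the widest gap is a 5.8-fold higher number from compound 1 to compound 3 (0.77 log units; beyond the scatter), beyond it.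

Compound 4 (`COc1ccccc1OC(=O)N1CCC(c2nc(-c3ccc4ccccc4n3)no2)CC1`) carries 2-methoxyphenoxy in place of (3-chloropyridin-2-yl)amino on a carbonyl carbon. For the measured compounds named here, no measured step tests this exchange directly. The steps beyond the scatter, a 6.5-fold higher number from compound 1 to compound 2 (0.81 log units; beyond the scatter) and a 5.8-fold higher number from compound 1 to compound 3 (0.77 log units; beyond the scatter), are modest, and both leave the (2-isopropylphenyl)amino group, which compound 4 also lacks. Going by the values given here, the one step between two other replacement groups is a 1.1-fold lower number from compound 2 to compound 3 (0.04 log units; within the scatter), within the scatter. No step beyond the scatter is therefore expected in this assay, although the range stays wide. The expected step is a 1.1-fold lower number from compound 3 to compound 4 (0.05 log units; within the scatter). Compound 4 is estimated at 2500 nM, with an expected range of 900 nM to 7500 nM.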

Compound 4, half-maximal inhibitory concentration: 250 nM
For compound 4 the middle estimate is 10-fold (1.00 log units) above the measured one; measured number outside the range, below it.
By their numbers in this assay, from the lowest: compounds 4 and 1 (each within the scatter of the next); then compounds 3 and 2 (each within the scatter of the next).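

Keeping the 2-methoxyphenyl ring and exchanging only its (methyl)amino link for the oxygen of 2-methoxyphenoxy gives a 12-fold lower number from compound 2 to compound 4 (1.09 log units; beyond the scatter) in this assay, so on this carbonyl carbon the linking atom matters as much as the aryl group, a point the earlier compounds could not separate; the exchange from (3-chloropyridin-2-yl)amino gives a similarly large an 11-fold lower number from compound 3 to compound 4 (1.05 log units; beyond the scatter). With 0 hydrogen-bond donors in the entering group, 2-methoxyphenoxy still gives a 1.9-fold lower number from compound 1 to compound 4 (0.28 log units; within the scatter), so an amino link is not needed to reach the range of compound 1. No measured evidence accounts for these steps.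

The compounds shown leave open whether the oxygen link gives the same gain with other aryl groups, such as 2-isopropylphenoxy. A (2-methoxyphenyl)amino group, with the same ring on an unmethylated nitrogen, would show how much of the step belongs to the methyl group.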